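The source may hold more compounds than are shown below. What is called first, only, known or untested is meant among the compounds shown, and "the series" means these compounds.

Measured in a functional assay on DU-145 cells (Homo sapiens) for inhibition, read by trypan blue exclusion, with a stated time of 96 h; a lower number here means a stronger inhibitor of growth, a higher number a weaker inhibitor of growth:
- compound 1 `Cc1ccc(S/C(=C/c2ccc(Cl)c(Cl)c2)C(=O)c2ccc(Br)cc2)cc1`: 50000 nM
- compound 2 `COc1ccc(/C=C(/Sc2ccc(C)cc2)C(=O)c2ccc(Br)cc2)cc1`: 50000 nM

In this assay, compound 1 stands level with compound 2 at 50000 nM. Compound 3 `Cc1ccc(S/C(=C/c2ccc(Cl)cc2)C(=O)c2ccc(Br)cc2)cc1` has chloro in place of methoxy on an aromatic carbon, para to a large group (chloro in place of methoxy on an aromatic carbon). Within the data shown here, only one measured step bears on this change: no change at the digits printed from compound 1 to compound 2 (within the scatter), where 4-methoxyphenyl replaced 3,4-dichlorophenyl. Among the measured compounds shown here, with that step as the only guide, no change beyond the scatter is expected, and the expected size is no change at the digits printed from compound 2 to compound 3 (within the scatter). For compound 3 the estimated value is 50000 nM, with an expected range of 20000 nM to 100000 nM.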

Compound 3, concentration for 50% growth inhibition: 10000 nM
Compound 3: the middle estimate sits 5.0-fold (0.70 log units) above what was measured; the measured number lies below the stated range.
By their numbers in this assay, from the lowest: compound 3; then compounds 1 and 2 (each within the scatter of the next).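

The ring on the double-bonded chain carbon is not indifferent to its substituents in this assay, although the level values of compounds 1 and 2 gave no sign of this. The 4-chlorophenyl group gives a 5.0-fold lower number from compound 2 to compound 3 (0.70 log units; beyond the scatter) when it replaces 4-methoxyphenyl, and removing one chloro from the 3,4-dichlorophenyl group gives a 5.0-fold lower number from compound 1 to compound 3 (0.70 log units; beyond the scatter) in the same direction.

On these data alone, whether a fluoro or a nitrile at this place would match chloro remains open, as does whether the shift holds with the 4-bromophenyl group on the carbonyl replaced. Nothing available accounts for the shift.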